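A Smaller Group Where Compound 2 Carries Only Hydrogen

This account rests on a few compounds, and the source may have more. Where it says the series, first, only, none or still open, it means among the compounds named here.

Compound 1: `CCCCOC(=O)NS(=O)(=O)c1ccc(CCC)cc1-c1ccc(Cn2c(-c3nccs3)nc3ccccc32)cc1`, 5.1 nM
Compound 2: `CCCCOC(=O)NS(=O)(=O)c1ccc(CCC)cc1-c1ccc(Cn2cnc3ccccc32)cc1`, 29 nM
Compound 3: `CCCCOC(=O)NS(=O)(=O)c1ccc(CCC)cc1-c1ccc(Cn2c(CC)nc3ccccc32)cc1`, not yet measured

Of the compounds shown here, two have been measured in an assay on membranes from HEK293 cells for displacement of a labelled ligand from Type-2 angiotensin II receptor (Homo sapiens), read by radioligand binding; on this read-out higher numbers stand for weaker inhibition and lower numbers for stronger inhibition. Compound 1 `CCCCOC(=O)NS(=O)(=O)c1ccc(CCC)cc1-c1ccc(Cn2c(-c3nccs3)nc3ccccc32)cc1` gives 5.1 nM. Compound 2 `CCCCOC(=O)NS(=O)(=O)c1ccc(CCC)cc1-c1ccc(Cn2cnc3ccccc32)cc1` gives 29 nM, the higher of the two numbers. The step of a 5.7-fold higher number from compound 1 to compound 2 (0.75 log units; beyond the scatter) is hydrogen in place of 1,3-thiazol-2-yl on an aromatic carbon, and it weakened binding beyond the scatter.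

Compound 3 `CCCCOC(=O)NS(=O)(=O)c1ccc(CCC)cc1-c1ccc(Cn2c(CC)nc3ccccc32)cc1` differs from compound 2 by ethyl in place of hydrogen on an aromatic carbon, a change that reads 1H-benzimidazol-1-yl to 2-ethyl-1H-benzimidazol-1-yl. For the measured compounds named here, the only measured step that bears on it is a 5.7-fold higher number from compound 1 to compound 2 (0.75 log units; beyond the scatter), where a group on this same carbon was worth a modest gain over bare hydrogen. Ethyl is a different and smaller group than 1,3-thiazol-2-yl, so the expected step of a 2.4-fold lower number from compound 2 to compound 3 (0.38 log units; beyond the scatter) is downward but not as large as that one. Compound 3 is therefore estimated at 12 nM in this assay, with a range from 4 nM to 40 nM.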

Compound 3, inhibition constant: 11 nM
The estimate for compound 3 lay 1.1-fold (0.04 log units) above the measured number; the range from low to high includes it.
By their numbers in this assay, from the lowest: compound 1; then compound 3; then compound 2.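

In this assay, a small chain on this aromatic carbon, placed between two ring nitrogen atoms, is already enough to strengthen binding: ethyl in place of hydrogen gives a 2.6-fold lower number from compound 2 to compound 3 (0.42 log units; beyond the scatter). The gain seen earlier with 1,3-thiazol-2-yl therefore does not need a ring at this carbon, since ethyl has no ring and only 2 heavy atoms. The ring group still keeps an edge, as ethyl in place of 1,3-thiazol-2-yl gives a 2.2-fold higher number from compound 1 to compound 3 (0.33 log units; beyond the scatter), which places ethyl partway between hydrogen and 1,3-thiazol-2-yl among these three compounds.

No separate measurement bears on why the three groups fall in this order. The compounds shown leave open whether a longer chain such as n-butyl would continue the gain from hydrogen to ethyl or lose it, and whether an amine or a carboxylic acid would be tolerated on this carbon at all.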